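Working notes: the step from compound 2 to compound 4

This account rests on a few compounds, and the source may have more. Where it says the series, first, only, none or still open, it means among the compounds named here.

Compound 1 `CN(C)C(=O)c1cc2cnc(Nc3ccc(NC(=O)C4(C(=O)Nc5cccc(F)c5)CC4)cc3)nc2n1C1CCCC1` in a functional assay on OVCAR-5 cells (Homo sapiens) for inhibition, read by CCK-8 assay, with a stated time of 72 h, tested at 10 uM (a higher number here means more inhibition of growth at the concentration tested, a lower number less inhibition of growth), gives 85.6%
Compound 2 `CN(C)C(=O)c1cc2cnc(Nc3ccc(NC(=O)C4(C(=O)Nc5cccc(O)c5)CC4)cc3)nc2n1C1CCCC1` gives 86%
Compound 3 `Nc1ccc(NC(=O)C2(C(=O)Nc3ccc(F)cc3)CC2)cc1F` gives 9.7%

In this assay compound 2 gives 86% and compound 1 gives 85.6%; these two values lie within the scatter of each other. Compound 3 gives 9.7%. The gap between that value and the value of compound 2 lies beyond the scatter. Compound 4 `CN(C)C(=O)c1cc2cnc(Nc3ccc(NC(=O)C4(C(=O)Nc5ccc(Cl)c(C(F)(F)F)c5)CC4)cc3)nc2n1C1CCCC1` carries 4-chloro-3-(trifluoromethyl)phenyl in place of 3-hydroxyphenyl on an amide-type nitrogen.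

Going by the values given here, only one measured step touches this aryl group: a number 0.4 percentage points higher from compound 1 to compound 2 (within the scatter), with hydroxy in place of fluoro on an aromatic carbon. Compound 3 lacks the core of compound 1 and gives no matched comparison for this change. Among the compounds with values here, the new change is larger than that single swap, and no measured compound carries the entering group, so the evidence is thin. Because of the small step of a number 0.4 percentage points higher from compound 1 to compound 2 (within the scatter) no step beyond the scatter is expected, with a slight lean to the lower side and a wide range on that side. The expected step is a number 4 percentage points lower from compound 2 to compound 4 (within the scatter) in this estimate. Compound 4 is estimated at 82% (expected range 62% to 95%).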

Compound 4, percent growth inhibition at one concentration: 48%
The estimate for compound 4 lay 34 percentage points above the measured number; the measured number lies below the stated range.
By their numbers in this assay, from the lowest: compound 3; then compound 4; then compounds 1 and 2 (each within the scatter of the next).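

Working notes, continued. In this assay, this position on the amide-type nitrogen proves sensitive to the aryl group, which the earlier swap of hydroxy for fluoro, a number 0.4 percentage points higher from compound 1 to compound 2 (within the scatter), did not reveal. Placing 4-chloro-3-(trifluoromethyl)phenyl there instead of 3-hydroxyphenyl gives a number 38 percentage points lower from compound 2 to compound 4 (beyond the scatter), and placing it there instead of 3-fluorophenyl gives a number 37.6 percentage points lower from compound 1 to compound 4 (beyond the scatter), so the loss of growth inhibition appears against both of these closely matched reference compounds. The data at hand offer no measurement that accounts for this loss.

The entering group differs from both earlier aryl groups in more than one feature, and the compounds shown do not separate the contribution of the chloro group from that of the trifluoromethyl group; a phenyl carrying only one of these would divide the step between them. Also open, as far as these compounds go, is how the position responds to a different kind of group, such as an aminophenyl or a carboxylic acid on the phenyl ring, and whether any such group keeps growth inhibition at the level of compound 2, which gives 86%.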